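Replacing a small amine with a linked two-ring amine

A few compounds are considered here, and "the series" means these few. Any claim that something is new, unique, unknown or untested is made for them only; others in the source may bear on it.

Measured so far in a functional assay on DU-145 cells (Homo sapiens) for antiproliferative activity, read by MTT assay, with a stated time of 72 h; on this read-out lower numbers stand for stronger inhibition and higher numbers for weaker inhibition:
- Compound 1 `COc1cc2c(Nc3ccc(C#N)cc3)ncnc2cc1OCCCN(C)C` gives 35300 nM.
- Compound 2 `COc1cc2c(Nc3ccc(C#N)cc3)ncnc2cc1OCCCN(C)Cc1ccccc1` gives > 100000 nM, which is a limit of the assay and not a number.
- Compound 3 `COc1cc2c(Nc3ccc(C#N)cc3)ncnc2cc1OCCCN1CCC(N(C)C)CC1` gives 28300 nM.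

Among the two numbers given, compound 1 stands highest, with compound 3 nearest at a 1.2-fold lower number from compound 1 to compound 3 (0.10 log units; within the scatter). The limit for compound 2 is told by the limit of > 100000 nM in this assay, at which 1 of the 3 values shown sits.

Compound 4 `COc1cc2c(Nc3ccc(C#N)cc3)ncnc2cc1OCCCN1CCC(N2CCCCC2)CC1` has not yet been measured. It differs from compound 1 in one place: 4-(piperidin-1-yl)piperidin-1-yl in place of dimethylamino on a saturated chain carbon, three bonds along the chain from an oxygen on an aromatic ring.

Among the measured compounds shown here, two measured steps bear on this change. The step from compound 1 to compound 3 replaces the same dimethylamino at the same place with a ring-bearing amine and gives a 1.2-fold lower number from compound 1 to compound 3 (0.10 log units; within the scatter). The step to a benzyl-bearing amine gives an at least 2.8-fold higher number from compound 1 to compound 2 (0.45 log units; beyond the scatter), and an at least 3.5-fold lower number from compound 2 to compound 3 (0.54 log units; beyond the scatter) shows the ring-bearing amine doing better than the benzyl one. A larger ring system at this place has so far not changed the number beyond the scatter, so the step in this assay for compound 4 is expected to be a 1.1-fold lower number from compound 1 to compound 4 (0.04 log units; within the scatter). For compound 4 the estimate is 32000 nM, with a range from 11000 nM to 95000 nM.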

Compound 4, half-maximal inhibitory concentration: 15600 nM
Beside the measured number, compound 4's estimate is 2.1-fold (0.31 log units) above it; low and high end bracket the measured number.
By their numbers in this assay, from the lowest: compounds 4, 3 and 1 (each within the scatter of the next, the first and the last beyond it). At a limit, above all of these: compound 2.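

Of the replacements shown for dimethylamino at this place, on a saturated chain carbon three bonds along the chain from an oxygen on an aromatic ring, only 4-(piperidin-1-yl)piperidin-1-yl lowers the number beyond the scatter in this assay, with a 2.3-fold lower number from compound 1 to compound 4 (0.35 log units; beyond the scatter). Piperidin-1-yl in place of dimethylamino on a saturated ring carbon gives a 1.8-fold lower number from compound 3 to compound 4 (0.26 log units; within the scatter), while the benzyl(methyl)amino compound stays well behind, with an at least 6.4-fold lower number from compound 2 to compound 4 (0.80 log units; beyond the scatter). That last step is only a minimum, resting on a limit of the assay for compound 2 and not on a number: the limit of > 100000 nM in this assay, at which 1 of the 4 values shown sits.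

The compounds shown leave open whether a morpholine or a piperazine could take the place of the outer piperidine ring, and whether a longer chain would keep the step. With this assay alone, the cause of the step stays unknown.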